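The source may report more compounds than this note shows. Statements on the series, on what has been measured and on what is new or still open speak of the compounds shown alone.

Compound 2 `COC(=O)C(Cc1cccc(C(=N)N)c1)C(/C=C/c1ccccc1)NC(=O)c1ccc(-c2cccc(OC)c2)cc1` gives 2200 nM in an assay on isolated protein (Oryctolagus cuniculus) for inhibition of Trypsin (Homo sapiens); a higher number here means a weaker inhibitor, a lower number a stronger inhibitor. Compound 1 `CCc1cccc(-c2ccc(C(=O)NC(/C=C/c3ccccc3)C(Cc3cccc(C(=N)N)c3)C(=O)OC)cc2)c1` gives 2600 nM in this assay. The step of a 1.2-fold lower number from compound 1 to compound 2 (0.07 log units; within the scatter) shows that exchanging one small substituent for another on the outer part of the shared core left the inhibition essentially unchanged. Compound 2 thus has the lowest of the two numbers, but its difference from compound 1 lies within the scatter, so the two cannot be told apart. Compound 3 `CCOc1ccc(-c2ccc(C(=O)NC(/C=C/c3ccccc3)C(Cc3cccc(C(=N)N)c3)C(=O)OC)cc2)cc1` carries 4-ethoxyphenyl in place of 3-methoxyphenyl on an aromatic carbon. For the measured compounds named here, only the step from compound 1 to compound 2 bears on this change, and it lay within the scatter, so a change of similar kind is expected to move this assay little, with no step beyond the scatter in either direction. Compound 3 is therefore expected to give about 2300 nM in this assay, within a range from 1000 nM to 5500 nM. For compound 3 the expected step of a 1.0-fold higher number from compound 2 to compound 3 (0.02 log units; within the scatter) is estimated to stay within the scatter.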

Compound 3, half-maximal inhibitory concentration: 2800 nM
Beside the measured number, compound 3's estimate is 1.2-fold (0.09 log units) below it; the range from low to high includes it.
By their numbers in this assay, from the lowest: compounds 2, 1 and 3 (each within the scatter of the next).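

Compounds 1 and 2 both carry their substituent on the 3-position of the outer ring, so they could not show whether moving it changes the result. Compound 3 brings that test: in this assay 4-ethoxyphenyl, with its substituent para to a large group, gives a 1.3-fold higher number from compound 2 to compound 3 (0.10 log units; within the scatter) and also a 1.1-fold higher number from compound 1 to compound 3 (0.03 log units; within the scatter), so neither this new place nor the one extra heavy atom separates the compounds. No measurement shown here accounts for this lack of separation.

Going by these compounds, because compound 3 changes the place and the substituent together, the effect of each alone remains open. Also open, on these data alone, is whether an amine, a carboxylic acid or a much longer chain on this ring would move the number beyond the scatter.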